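A few compounds are considered here, and "the series" means these few. Any claim that something is new, unique, unknown or untested is made for them only; others in the source may bear on it.

Measured so far:
Compound 1 `Cc1cc(C)cc(S(=O)(=O)c2c(C(=O)Nc3ccccc3O)[nH]c3ccc(Cl)cc23)c1`: 19700 nM
Compound 2 `Cc1cc(C)cc(S(=O)(=O)c2c(C(=O)Nc3cccc(O)c3)[nH]c3ccc(Cl)cc23)c1`: 24600 nM

Both numbers come from an ADME assay on MT4 cells (Homo sapiens) for cytotoxicity, read by MTT assay (on this read-out lower numbers stand for higher toxicity in this test and higher numbers for lower toxicity in this test), and are the only data so far. Among the measured compounds shown here, compound 2 at 24600 nM stands level with compound 1, its only neighbour. The change between them is a 1.2-fold higher number from compound 1 to compound 2 (0.10 log units; within the scatter) and so the two cannot be told apart.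

The next compound to consider is compound 3 `Cc1cc(C)cc(S(=O)(=O)c2c(C(=O)Nc3ccc(O)cc3)[nH]c3ccc(Cl)cc23)c1` which keeps the shared core. Its one difference is 4-hydroxyphenyl in place of 3-hydroxyphenyl on an amide-type nitrogen or, in short, 4-hydroxyphenyl in place of 3-hydroxyphenyl on an amide-type nitrogen.

For the measured compounds named here, only one measured step is of the same kind: a 1.2-fold higher number from compound 1 to compound 2 (0.10 log units; within the scatter) with 3-hydroxyphenyl in place of 2-hydroxyphenyl at that same place. A single step is thin evidence, but it gives no reason to expect a change beyond the scatter in this assay here. The estimated change is a 1.1-fold lower number from compound 2 to compound 3 (0.05 log units; within the scatter) and it is expected to be too small to read as a real difference. Compound 3 is expected at 22000 nM with an estimated range from 11000 nM to 45000 nM for the coming measurement.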

Compound 3, half-maximal cytotoxic concentration: 18100 nM
Compound 3: the middle estimate sits 1.2-fold (0.08 log units) above what was measured, and the stated range covers the measured number.
By their numbers in this assay, from the lowest: compounds 3, 1 and 2 (each within the scatter of the next).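

With 4-hydroxyphenyl on the amide-type nitrogen, the set now holds the 2-, 3- and 4-hydroxyphenyl groups at this one place, so all three arrangements of the same atoms can be compared in this assay (compound 3 against its two neighbours: a 1.4-fold lower number from compound 2 to compound 3 (0.13 log units; within the scatter) and a 1.1-fold lower number from compound 1 to compound 3 (0.04 log units; within the scatter)). Together with the earlier step, these results show that none of the three pairs can be told apart, so where the hydroxyl group sits on this phenyl ring makes no readable difference to the number in this test for compounds 1, 2 and 3. Nothing measured here explains this lack of a readable change.

Going by these compounds, what remains open is whether a different group at this same place would give a change larger than the usual scatter, for example plain phenyl, methoxyphenyl, aminophenyl, a phenyl ring carrying a carboxylic acid, or a longer chain such as benzyl or phenethyl. These three compounds also cannot show whether the same flat result would hold if the hydroxyphenyl groups were attached to a changed version of the shared core.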